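Trimming the Acyl Chain of Compound 1

This account rests on a few compounds, and the source may have more. Where it says the series, first, only, none or still open, it means among the compounds named here.

In a functional assay on NCI-H23 cells (Homo sapiens) for cytotoxicity, read by sulforhodamine B assay, with a stated time of 72 h (on this read-out lower numbers stand for stronger inhibition of growth and higher numbers for weaker inhibition of growth), compound 1 `CCCCCCCCC(=O)N1c2ccccc2CCC1C(=O)Nc1ccccc1C(F)(F)F` gives 4220 nM, the second highest of the three numbers. Going by the values given here, compound 3 `O=C(Nc1cc(C(F)(F)F)cc(C(F)(F)F)c1)C1CCc2ccccc2N1C(=O)c1ccccc1` gives 2130 nM, within the scatter of compound 1, while compound 2 `CCCCCCCCC(=O)N1c2ccccc2CCC1C(=O)Nc1ccccc1O` gives 55800 nM; the only measured step, a 13-fold higher number from compound 1 to compound 2 (1.12 log units; beyond the scatter), concerns the aromatic substituent and not the chain. Compound 4 `CCC(=O)N1c2ccccc2CCC1C(=O)Nc1ccccc1C(F)(F)F` differs from compound 1 by hydrogen in place of hexyl on a saturated chain carbon, two bonds along the chain from a carbonyl carbon. Among the compounds with values here, no measured step alters this chain, so the single known step has no direct bearing, and compound 3 shows only that another acyl group can give a similar number. Compound 4 is therefore expected to give 8000 nM, with a range from 2500 nM to 30000 nM. The step expected here, a 1.9-fold higher number from compound 1 to compound 4 (0.28 log units; within the scatter), is modest and carries wide uncertainty.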

Compound 4, concentration for 50% growth inhibition: > 80000 nM
Compound 4 ended at the assay's limit; the forecaster's own chance of this, stated with the estimate: 5%; middle value at least 10-fold (1.00 log units) from the limit.
By their numbers in this assay, from the lowest: compounds 3 and 1 (each within the scatter of the next); then compound 2. At a limit, above all of these: compound 4.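

In this assay, the hexyl part of the acyl chain proves to matter: hydrogen in its place, on a saturated chain carbon, two bonds along the chain from a carbonyl carbon, brings an at least 18-fold higher number from compound 1 to compound 4 (1.27 log units; beyond the scatter). Going by these compounds alone, this is the first measured step on the chain, and until now only the aromatic substituent had been seen to change the number. The value of compound 4 is a limit of the assay and not a number: the limit of > 80000 nM in this assay, at which 1 of the 4 values shown sits.

As far as these compounds go, what remains open is how the number follows chain length. A butyl group in place of hexyl, or a longer chain such as decyl, would test this.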